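The source may report more compounds than this note shows. Statements on the series, on what has been measured and on what is new or still open speak of the compounds shown alone.

The three measured compounds share a core in which a heterocyclic head is linked through a sulfur-containing chain to a dichlorinated anilide tail, and they were tested in an assay on NK92 cells for inhibition of interleukin-2 (Homo sapiens), read by AlphaScreen, with stated times of 30 min and 1 h; a higher number here means a weaker inhibitor, a lower number a stronger inhibitor. Compound 1 `Cn1nc(Cc2nnc(SCC(=O)Nc3ccc(Cl)cc3Cl)n2CCCO)c2ccccc2c1=O` carries a 3-hydroxypropyl group on the aromatic nitrogen. In this assay compound 1 reaches only the limit > 30000 nM, which is a limit and not a number. Compound 2 `Cn1nc(Cc2nnc(SCC(=O)Nc3ccc(Cl)cc3Cl)n2CCC(=O)O)c2ccccc2c1=O` differs from compound 1 by carboxy in place of hydroxymethyl on a saturated chain carbon, two bonds along the chain from an aromatic nitrogen. In this assay compound 2 likewise stops at the limit > 30000 nM. The step that the two limits leave unreadable from compound 1 to compound 2 therefore cannot be read as a size. Compound 3 `Cn1nc(Cc2nnc(SCCCCCCCC(=O)Nc3ccc(Cl)cc3Cl)n2CCCO)c2ccccc2c1=O` has a longer chain between the sulfur and the anilide; how its core differs from that of compound 1 is not broken down here. In this assay compound 3 also sits at the limit > 30000 nM. Compound 4 `Cn1nc(Cc2nnc(SCCCCCCCC(=O)Nc3ccc(Cl)cc3Cl)n2CCC(=O)O)c2ccccc2c1=O`, not yet measured, differs from compound 3 by carboxy in place of hydroxymethyl on a saturated chain carbon, two bonds along the chain from an aromatic nitrogen, the same change as from compound 1 to compound 2, at the same place. With all three measured values at the limit of > 30000 nM in this assay, at which 3 of the 3 values shown sit, nothing shows the change helping or hurting. The step that the limit leaves unreadable from compound 3 to compound 4 is expected to be unreadable in the same way, because the earlier step that the two limits leave unreadable from compound 1 to compound 2 was unreadable and compound 3 already sits at the limit of > 30000 nM in this assay, at which 3 of the 3 values shown sit. Compound 4 is therefore estimated near 40000 nM. For compound 4 the range 15000 nM to 150000 nM is expected, most likely reported as a limit only.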

Compound 4, half-maximal inhibitory concentration: 14300 nM
The estimate for compound 4 lay 2.8-fold (0.45 log units) above the measured number; the measured number lies below the stated range.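

On the core of compound 3, with its longer chain, swapping hydroxymethyl for carboxy gives in this assay an at least 2.0-fold lower number from compound 3 to compound 4 (0.32 log units; beyond the scatter), and the true size of the step may be larger, since compound 3 gives only a limit and not a number. The same swap on the core of compound 1 cannot be sized, because neither end of that step gives a number: the limit of > 30000 nM in this assay, at which 3 of the 4 values shown sit. So the change is seen to work on one core only, and this single readable pair does not show that it carries from one core to another: it may help on the core of compound 1 too, with the effect hidden from view, or it may need the longer chain.

From the compounds shown here alone, whether an amine or a methyl ester at the same place, on a saturated chain carbon, two bonds along the chain from an aromatic nitrogen, would lower the number as the carboxylic acid does remains open. Also open, going by these compounds, is whether a longer chain on the sulfur than that of compound 4, or one of intermediate length, would take the number lower still.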